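The source may report more compounds than this note shows. Statements on the series, on what has been measured and on what is new or still open speak of the compounds shown alone.

Compound 1 `CCC(c1ccc(-c2cscc2C)cc1)n1ccnc1` carries a five-membered sulfur ring joined to its six-membered carbon ring. Among the measured compounds shown here, in an assay for inhibition of steroid 17-alpha-hydroxylase/17,20 lyase (Homo sapiens), using NADPH, tested at 2 uM (a higher number here means a stronger effect of the compound at the concentration tested, a lower number a weaker effect), compound 1 gives 84%, the second highest of the three numbers measured so far. For the measured compounds named here, its nearest neighbour is compound 3 `CCC(c1ccc(-c2cscc2C)cc1F)n1ccnc1`, which in this assay gives 92%; the only single change between them, fluoro in place of hydrogen on an aromatic carbon, gives a number 8 percentage points higher from compound 1 to compound 3 (within the scatter). The furthest is compound 2 `COc1ccc(-c2csc(Cn3ccnc3)c2)cc1OC`, which in this assay gives 14%; it differs from compound 1 in several places at once, so its values alone show only that a differently built molecule of this family can fall far lower.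

Compound 4 `CCC(c1ccc(-c2ccc(SC)s2)cc1)n1ccnc1` is the new compound. Against compound 1 the change is 5-(methylsulfanyl)thiophen-2-yl in place of 4-methylthiophen-3-yl on an aromatic carbon. Going by the values given here, no measured step touches this part of the molecule: the one step, from compound 1 to compound 3, sits on the six-membered ring, not on the sulfur ring, so it does not bear on the swap. The values of compound 2 warn that rearranging the sulfur ring can matter, without saying how much.

On this slim footing, compound 4 is expected to give 76% in this assay, with a likely range from 45% to 94%, a step of a number 8 percentage points lower from compound 1 to compound 4 (within the scatter) that is estimated to stay within the scatter.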

Compound 4, a percentage reported as inhibition, at one concentration (the size of the read-out at that concentration, not a potency): 3%
Compound 4: the middle estimate sits 73 percentage points above what was measured; the measured number lies below the stated range.
By their numbers in this assay, from the lowest: compound 4; then compound 2; then compounds 1 and 3 (each within the scatter of the next).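

In this assay, 5-(methylsulfanyl)thiophen-2-yl in place of 4-methylthiophen-3-yl gives a number 81 percentage points lower from compound 1 to compound 4 (beyond the scatter), the first direct sign that this position, on an aromatic carbon of the six-membered aromatic ring of carbon only, does not accept every sulfur ring alike. Both groups are a five-membered aromatic ring with one hetero atom, so keeping that kind of ring is not enough to keep the read-out; the swap changes the ring's point of attachment, the place of its side group and the side group itself, methyl against methylsulfanyl, all at once. Nothing available here explains the drop.

The compounds shown leave open which of these changes matters, a question that a thiophen-2-yl ring bearing methyl, or a 4-methylthiophen-3-yl ring with methylsulfanyl in place of its methyl, could help to separate. Going by these compounds, it also remains open how a side group of another kind on the sulfur ring, such as an amine or a longer carbon chain, would fare, and whether the fluoro group of compound 3 would make any difference alongside the new ring.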